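A few compounds are considered here, and "the series" means these few. Any claim that something is new, unique, unknown or untested is made for them only; others in the source may bear on it.

Going by the values given here, compound 2 `Nc1ccccc1/C=C/c1cccc(O)c1` stands at the top of the two numbers measured so far, though the gap to compound 1 `Oc1cccc(/C=C/c2ccccc2O)c1` lies within the scatter, so the two cannot be told apart. In an ADME assay on HEK293 cells (Homo sapiens) for inhibition, read by MTT assay, with a stated time of 2 days (on this read-out higher numbers stand for weaker inhibition and lower numbers for stronger inhibition), compound 1 gives 18 ug/mL and compound 2 gives 20 ug/mL. Compound 3 `COc1ccccc1/C=C/c1cccc(O)c1` differs from compound 2 by methoxy in place of amino on an aromatic carbon. Among the compounds with values here, only one measured step bears on this: a 1.1-fold higher number from compound 1 to compound 2 (0.05 log units; within the scatter), an exchange of one small group for another that left the number unmoved. A similar outcome is expected here, no change at the digits printed from compound 2 to compound 3 (within the scatter). Compound 3 is therefore estimated at 20 ug/mL, most likely between 11 ug/mL and 36 ug/mL.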

Compound 3, half-maximal inhibitory concentration: 24 ug/mL
Beside the measured number, compound 3's estimate is 1.2-fold (0.08 log units) below it; the range from low to high includes it.
By their numbers in this assay, from the lowest: compounds 1, 2 and 3 (each within the scatter of the next).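

With methoxy on this aromatic carbon, this assay shows a 1.2-fold higher number from compound 2 to compound 3 (0.08 log units; within the scatter), and putting methyl on the oxygen of the hydroxy group shows a 1.3-fold higher number from compound 1 to compound 3 (0.12 log units; within the scatter). The position therefore also tolerates a larger group with no hydrogen-bond donor: two heavy atoms instead of one leave hydroxy, amino and methoxy indistinguishable here. No available evidence bears on why these numbers stay so close. Going by these compounds, whether a carboxylic acid or a longer chain such as butoxy on this carbon would shift the number stays open, as does whether these exchanges would behave alike elsewhere on the shared core.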